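The compounds below may be only part of what the source reports. "The series", "measured", "known", "first", "only" and "open" are said of these compounds alone.

Two compounds share a core in which a free amino group on one benzene ring sits beside an amide. Compound 1 `Nc1ccccc1NC(=O)/C=C/c1ccc(CSc2ccc(Cl)cc2)cc1` carries a double bond between that amide and a second ring, and in a functional assay on A549 cells (Homo sapiens) for inhibition, read by CCK-8 assay, with a stated time of 72 h, tested at 2 uM (a lower number here means less inhibition of growth, a higher number more inhibition of growth at the concentration tested), compound 1 gives 55.3%, the higher of the two numbers seen. Compound 2 `Nc1ccccc1NC(=O)c1ccc(CSc2ccc(Br)cc2)cc1` lacks that double bond and carries bromo in place of chloro; in this assay compound 2 gives 33.2%. Compound 3 `CC(C)(C)c1ccc(SCc2ccc(/C=C/C(=O)Nc3ccccc3N)cc2)cc1` keeps the whole of compound 1 except for one exchange: tert-butyl in place of chloro on an aromatic carbon. Among the compounds with values here, no measured pair shows such an exchange on its own, so the step from compound 1 to compound 3 is expected to stay within the usual scatter, a number 1.7 percentage points higher from compound 1 to compound 3 (within the scatter). Compound 3 is therefore expected to give 57%, somewhere between 38% and 74%.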

Compound 3, percent growth inhibition at one concentration: 71.5%
Beside the measured number, compound 3's estimate is 14.5 percentage points below it, within the range that was stated.
By their numbers in this assay, from the lowest: compound 2; then compound 1; then compound 3.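

Exchanging one group at this position, para to a large group, changes growth inhibition on its own: with tert-butyl in place of chloro, this assay shows a rise of a number 16.2 percentage points higher from compound 1 to compound 3 (beyond the scatter). Within the data shown here, this is the first single-place comparison, and it shows that four carbons can replace one chlorine here without loss of inhibition. Nothing available explains the rise. Still open, from the compounds shown here alone, is how an amine, a carboxylic acid or a longer chain would fare at this position. Also open, going by these compounds, is whether tert-butyl would give a similar step without the double bond of compound 1.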